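Swapping 1,3-dicarboxypropyl for (pyridin-3-yl)methyl on the amide

A few compounds are considered here, and "the series" means these few. Any claim that something is new, unique, unknown or untested is made for them only; others in the source may bear on it.

Compounds in a functional assay on KB cells (Homo sapiens) for antiproliferative activity, read by MTT assay, with a stated time of 72 h, in the presence of a further agent that is not named here (a higher number here means a weaker inhibitor, a lower number a stronger inhibitor), so far
compound 1 `Nc1nc2[nH]c(CCSCCC(=O)NCc3ccccn3)cc2c(=O)[nH]1` gives 8930 nM
compound 2 `Nc1nc2[nH]c(CCSCCC(=O)N[C@@H](CCC(=O)O)C(=O)O)cc2c(=O)[nH]1` gives 324 nM
compound 3 `Nc1nc2[nH]c(CCSCC(=O)N[C@@H](CCC(=O)O)C(=O)O)cc2c(=O)[nH]1` gives 373 nM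
compound 4 `Nc1nc2[nH]c(CCSCC(=O)NCc3cccnc3)cc2c(=O)[nH]1` has no measurement yet

In this assay compound 3 gives 373 nM and compound 2 gives 324 nM so these two lie within the usual scatter of each other, although their linking chains differ. Compound 1 carries a clearly higher number than either.

Compound 4 keeps the core and chain of compound 3 and changes one group: (pyridin-3-yl)methyl in place of 1,3-dicarboxypropyl on an amide-type nitrogen with (pyridin-3-yl)methyl in place of 1,3-dicarboxypropyl on an amide-type nitrogen.

For the measured compounds named here, one measured step bears on this change. It shows a 28-fold lower number from compound 1 to compound 2 (1.44 log units; beyond the scatter) for the opposite kind of swap, where 1,3-dicarboxypropyl replaces (pyridin-2-yl)methyl on an amide-type nitrogen. Run in reverse, that large step points to a large rise in the number. Going by the values given here, the evidence is a single pair, however, and no compound with (pyridin-3-yl)methyl has a measured value, so the range stays wide.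

The expected change is a 21-fold higher number from compound 3 to compound 4 (1.33 log units; beyond the scatter) and it would mean a much weaker inhibitor. For compound 4 the estimate is 8000 nM with an expected range from 2000 nM to 30000 nM around it.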

Compound 4, half-maximal inhibitory concentration: 37500 nM
Compound 4: middle estimate off by 4.7-fold (0.67 log units), on the low side; measured number above the stated range.
By their numbers in this assay, from the lowest: compounds 2 and 3 (each within the scatter of the next); then compound 1; then compound 4.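

In this assay, the change on the amide-type nitrogen gives a 100-fold higher number from compound 3 to compound 4 (2.00 log units; beyond the scatter), so this swap leads to a much weaker inhibitor on this linking chain too. Until now, the only measured loss of this kind came from the pair with the longer chain and (pyridin-2-yl)methyl; now both measured pairs point the same way, with 1,3-dicarboxypropyl giving the lower number, and neither goes against it. The measurements shown offer no explanation for this large difference.

The swap removes a group with two carboxylic acids and a defined stereocentre and adds an aromatic ring, so the compounds shown cannot tell which of these features matters most. A group with a single carboxylic acid, the dimethyl ester of 1,3-dicarboxypropyl, or a plain benzyl group on the same nitrogen would help separate them, while the two pyridine attachments remain to be compared on one and the same chain.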